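A Smaller Ring on the Sulfonamide Nitrogen

The source may hold more compounds than are shown below. What is called first, only, known or untested is meant among the compounds shown, and "the series" means these compounds.

Of the compounds shown here, three built on one shared core have been tested in a functional assay on HT-29 cells (Homo sapiens) for antiproliferative activity, read by sulforhodamine B assay, with a stated time of 72 h; on this read-out lower numbers stand for stronger inhibition and higher numbers for weaker inhibition. Compound 1 `COc1ccc(NC(=S)NNc2nncc3ccccc23)cc1` gives 20 nM. Compound 2 `C(=C/c1ccccc1)\C(=N\Nc1nncc2ccccc12)c1ccccc1` gives 1.1 nM. Compound 3 `Cc1cc(C)nc(NS(=O)(=O)c2ccc(Nc3nncc4ccccc34)cc2)n1` gives 3.3 nM, which places it second highest of the three numbers: its nearest neighbour is compound 2, whose number is lower by a margin beyond the scatter, while compound 1 lies furthest away, with a number higher by a wider margin.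

Compound 4 `O=S(=O)(Nc1nccs1)c1ccc(Nc2nncc3ccccc23)cc1` has not yet been measured. It differs from compound 3 in a single place: 1,3-thiazol-2-yl in place of 4,6-dimethylpyrimidin-2-yl on a sulfonamide nitrogen. Among the measured compounds shown here, no pair of measured compounds differs in exactly this way, so there is no measured step to lean on; the three measured values only show that rather different groups on the shared core all give low numbers in this assay. The expected change is a 1.2-fold higher number from compound 3 to compound 4 (0.08 log units; within the scatter), a step not beyond the usual scatter. Compound 4 is therefore estimated at 4 nM, with a likely range from 1.5 nM to 12 nM.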

Compound 4, half-maximal inhibitory concentration: 34 nM
Compound 4: the middle estimate sits 8.5-fold (0.93 log units) below what was measured; the whole stated range lies below it.
By their numbers in this assay, from the lowest: compound 2; then compound 3; then compounds 1 and 4 (each within the scatter of the next).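

The group on the sulfonamide nitrogen clearly matters in this assay: placing 1,3-thiazol-2-yl where 4,6-dimethylpyrimidin-2-yl stood gives a 10-fold higher number from compound 3 to compound 4 (1.01 log units; beyond the scatter), a large step. The earlier compounds shown here could not show this, since no two of them differed in one place only, and the change here is sizeable even though both groups are aromatic rings with two hetero atoms and the same hydrogen-bond donor and acceptor counts. No measurement at hand explains the step.

This one swap changes several things at once, namely the ring size, the sulfur atom and the two methyl groups, so it remains open which of them accounts for the step. A plain pyrimidin-2-yl group without the methyl groups, or a simple phenyl ring, on the same nitrogen would help to tell these apart.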